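The source may report more compounds than this note shows. Statements on the series, on what has been measured and on what is new or still open speak of the compounds shown alone.

Working notes on the series. The series is read in a functional assay on DU-145 cells (Homo sapiens) for cytotoxicity, in the presence of a further agent that is not named here; on this read-out lower numbers stand for stronger inhibition and higher numbers for weaker inhibition. Within the data shown here, compound 1 `Clc1ccc(-c2cc(-c3cccnc3)nc(-c3cccs3)c2)o1` gives 13000 nM in this assay, which is the lowest of the two numbers so far; its nearest neighbour is compound 2 `Clc1ccc(-c2cc(-c3cccnc3)nc(-c3ccsc3)c2)o1`, which in this assay gives 21600 nM. Among the measured compounds shown here, the only measured step, a 1.7-fold higher number from compound 1 to compound 2 (0.22 log units; within the scatter), changes one thiophene attachment and stays within the scatter, so the two numbers show no order.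

Compound 3 `Clc1cccc(-c2cc(-c3ccc(Cl)o3)cc(-c3cccs3)n2)c1` is not yet measured. It differs from compound 1 by 3-chlorophenyl in place of pyridin-3-yl on an aromatic carbon. For the measured compounds named here, no measured step touches this position or this kind of exchange: the one step on record concerns the thiophen-2-yl group, not the pyridin-3-yl group, so nothing here tells how far a ring with one nitrogen against a carbon-only ring bearing a chlorine moves the read-out. On the numbers available, the working expectation is a step from compound 1 to compound 3 of a 1.2-fold higher number from compound 1 to compound 3 (0.06 log units; within the scatter) in this assay, that is, no step beyond the scatter, with a wide range. Compound 3 is therefore estimated at 15000 nM, with a range from 4000 nM to 60000 nM in this assay.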

Compound 3, half-maximal inhibitory concentration: 18100 nM
Beside the measured number, compound 3's estimate is 1.2-fold (0.08 log units) below it; the range from low to high includes it.
By their numbers in this assay, from the lowest: compounds 1, 3 and 2 (each within the scatter of the next).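

Among these compounds, this is the first measured exchange at the position next to the ring nitrogen, and in this assay it gives a 1.4-fold higher number from compound 1 to compound 3 (0.14 log units; within the scatter), so the two numbers show no order. Within this single pair, pyridin-3-yl, with its ring nitrogen and hydrogen-bond acceptor, and 3-chlorophenyl, with a carbon-only ring, a chlorine and no hydrogen-bond acceptor, cannot be told apart on this read-out while the 5-chlorofuran-2-yl and thiophen-2-yl groups stay in place. No information at hand accounts for this result.

The compounds shown leave open whether the chlorine and the loss of the ring nitrogen each have an effect that cancels in this pair, since plain phenyl, which would separate the two changes, is not among them. They also leave open whether this position responds at all to a group of another kind, such as a primary amine, a carboxylic acid or a longer alkyl chain, as every group seen here is a six-membered aromatic ring.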